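Chain length at the amide in two pyrrole cores

The source may hold more compounds than are shown below. What is called first, only, known or untested is meant among the compounds shown, and "the series" means these compounds.

Compound 1 `CCn1c(C(=O)NCC(=O)O)ccc1C(CC)(CC)c1ccc(C#CC(O)(CC)CC)c(C)c1` and compound 2 `CCn1c(C(=O)NCCC(=O)O)ccc1C(CC)(CC)c1ccc(C#CC(O)(CC)CC)c(C)c1` share a core and differ only in the acid chain, carboxymethyl in place of carboxy on a saturated chain carbon bound to an amide-type nitrogen. In an assay on cells for agonist activity at vitamin D3 receptor (Homo sapiens), read by microscopy (a lower number here means that less compound is needed, a higher number that more compound is needed for the effect), compound 1 gives 9.36 nM, while compound 2 gives 293 nM; the step is a 31-fold higher number from compound 1 to compound 2 (1.50 log units; beyond the scatter).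

Compound 3 `CCn1cc(C(CC)(CC)c2ccc(C#CC(O)(CC)CC)c(C)c2)cc1C(=O)NCC(=O)O` carries the same atoms as compound 1 joined differently; the difference between the two cores is not broken down here. In this assay compound 3 gives 54.3 nM, which stands between the values of compound 1 and compound 2.

Compound 4 `CCn1cc(C(CC)(CC)c2ccc(C#CC(O)(CC)CC)c(C)c2)cc1C(=O)NCCC(=O)O` is not yet measured. It differs from compound 3 by the same change, carboxymethyl in place of carboxy on a saturated chain carbon bound to an amide-type nitrogen, at the same place in words. Within the data shown here, the single measured instance of this change, a 31-fold higher number from compound 1 to compound 2 (1.50 log units; beyond the scatter), is the only guide, and whether it carries over to the core of compound 3 is unknown, so the expected step is taken as large but with wide bounds. Compound 4 is expected to give 1100 nM in this assay, the estimated step being a 20-fold higher number from compound 3 to compound 4 (1.31 log units; beyond the scatter), because compound 3 gives 54.3 nM and the earlier step was a 31-fold higher number from compound 1 to compound 2 (1.50 log units; beyond the scatter). The range is estimated from 300 nM to 4500 nM.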

Compound 4, half-maximal effective concentration: > 50 nM
Compound 4: only a limit was reported; the forecaster's own chance of this, stated with the estimate: 10%; the middle value is on the limit's open side.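

In this assay compound 4 gives > 50 nM, which is a limit of the assay and not a number. The step between compound 3 and compound 4 therefore cannot be read. The compounds shown leave open whether the change from carboxymethyl to 2-carboxyethyl on the core of compound 3 matches the only readable instance, a 31-fold higher number from compound 1 to compound 2 (1.50 log units; beyond the scatter).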